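Swapping the ring amine's thiophene arm for a cyclohexyl one

The source may hold more compounds than are shown below. What is called first, only, known or untested is meant among the compounds shown, and "the series" means these compounds.

Of the compounds shown here, two sharing one core have been measured in an assay on FRT cells with Cystic fibrosis transmembrane conductance regulator variant F508del (Homo sapiens) as the target, read by fluorescence, with a stated time of 25 min; on this read-out higher numbers stand for an effect only at larger amounts of compound and lower numbers for an effect already at smaller amounts. Compound 1 `COc1ccc(CN2CCc3nc(-c4ccccn4)nc(N4CCN(CC(N)=O)CC4)c3C2)cc1` gives 2300 nM. Compound 2 `CN(C)CCN1CCN(c2nc(-c3ccccn3)nc3c2CN(Cc2ccsc2)CC3)CC1` gives 200 nM, the lowest of the two numbers, and its gap to compound 1 lies beyond the scatter of the method. For the measured compounds named here, no single-point step between measured compounds is available, as compound 1 and compound 2 differ in more than one place. Compound 3 `CN(C)CCN1CCN(c2nc(-c3ccccn3)nc3c2CN(CC2CCCCC2)CC3)CC1` is drawn from compound 2 by one change: cyclohexyl in place of thiophen-3-yl on a saturated chain carbon bound to an amine nitrogen in a ring. Going by the values given here, nothing measured so far shows how this assay responds to an aromatic versus a saturated ring at that position, so the expectation rests on compound 2 alone. The author expects a small step from compound 2 to compound 3, most likely toward a somewhat higher number, but possibly none beyond the scatter, giving a 1.8-fold higher number from compound 2 to compound 3 (0.24 log units; within the scatter). Compound 3 is therefore estimated at 350 nM, with a plausible range from 100 nM to 1200 nM.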

Compound 3, half-maximal effective concentration: 900 nM
Compound 3: middle estimate off by 2.6-fold (0.41 log units), on the low side, within the range that was stated.
By their numbers in this assay, from the lowest: compound 2; then compound 3; then compound 1.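

In this assay, cyclohexyl in place of thiophen-3-yl on a saturated chain carbon bound to an amine nitrogen in a ring gives a 4.5-fold higher number from compound 2 to compound 3 (0.65 log units; beyond the scatter). For the compounds shown here, this is the first single-place comparison, and it shows that the read-out responds to the identity of the ring at this position, with compound 2, carrying the five-membered aromatic ring, giving the lower number of the pair. Nothing measured here accounts for the size or direction of this step.

The change replaces a five-membered aromatic ring holding sulfur with a six-membered non-aromatic ring of carbon only, so these features remain unseparated. Where phenyl or cyclopentyl at this position would fall relative to compound 2 and compound 3 remains open.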